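Methoxy to hydroxy in compound 3: working notes

The compounds below may be only part of what the source reports. "The series", "measured", "known", "first", "only" and "open" are said of these compounds alone.

Within the data shown here, in a physicochemical assay for lipophilicity, at pH 7.4 (a lower number here means a more polar compound, a higher number a more lipophilic compound), compound 2 `COc1cc(C)c2cnc(Nc3ccc(N4CCNCC4)cc3)nc2c1C1CCCC1` stands at 2.32 and holds the lower of the two numbers so far. Compound 1 `COc1cc(C)c2cnc(Nc3ccc(N4CCN(C(C)=O)CC4)cc3)nc2c1C1CCCC1` stands at 3.77 on the same scale.

The next structure is compound 3 `Cc1cc(O)c(C2CCCC2)c2nc(Nc3ccc(N4CCNCC4)cc3)ncc12` and its difference from compound 2 reads (hydrogen in place of methyl on an oxygen on an aromatic ring); in words, hydrogen in place of methyl on an oxygen on an aromatic ring, or methoxy to hydroxy.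

Among the measured compounds shown here, only one measured step is available: a number 1.45 log units lower from compound 1 to compound 2 (beyond the scatter) with hydrogen in place of acetyl on an amine nitrogen in a ring. That step is large and beyond the scatter, but it concerns acetyl rather than methyl, and a nitrogen rather than an oxygen. It therefore suggests a direction at most and gives no measure of size. For the measured compounds named here, no measured pair covers methoxy to hydroxy itself.

A moderate downward move in this assay is expected, well short of the large step above, and the estimated step is a number 0.47 log units lower from compound 2 to compound 3 (beyond the scatter) in this measure. Compound 3 is expected at 1.85 with an estimated range of 1.4 to 2.3 in this measure.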

Compound 3, distribution coefficient: 1.39
Compound 3: middle estimate off by 0.46 log units, on the high side; measured number below the stated range.
By their numbers in this assay, from the lowest: compound 3; then compound 2; then compound 1.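

The oxygen on the aromatic ring proves to be a second place in the series where one change moves the number in this assay beyond the scatter: methoxy to hydroxy gives a number 0.93 log units lower from compound 2 to compound 3 (beyond the scatter) with the rest of the structure held constant. The earlier step of a number 1.45 log units lower from compound 1 to compound 2 (beyond the scatter) came from the amine nitrogen in a ring and said nothing about this oxygen, so the two places now have separate measured steps, both downward and both with hydrogen entering. Nothing available bears on why the change at the oxygen gives a step of this size.

Going by these compounds, what remains open is how this position responds to other groups on the oxygen, such as ethyl, a longer chain or a chain ending in an amine or a carboxylic acid, since methyl and hydrogen are the only two seen there. Also open, on these data alone, is whether methoxy to hydroxy gives a similar step when acetyl sits on the amine nitrogen in a ring, as compound 3 and compound 1 differ in two places and cannot be compared directly.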